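The source may report more compounds than this note shows. Statements on the series, on what has been measured and on what is new or still open speak of the compounds shown alone.

Measured so far:
compound 1, `CCCCCOc1cccc2ccc(N)nc12`: 580 nM
compound 2, `CC(CC(C)(C)C)Oc1cccc2ccc(N(C)C)nc12`: > 2000 nM

For the measured compounds named here, in an assay on cells with melanin-concentrating hormone receptor 1 (Homo sapiens) as the target, read by radioligand binding (a lower number here means a stronger inhibitor, a higher number a weaker inhibitor), compound 1 gives 580 nM and is the only compound of the pair for which a number, rather than a limit, exists. Compound 2 is reported only as a limit of the limit of > 2000 nM in this assay, at which 1 of the 2 values shown sits, so its standing relative to compound 1 cannot be put into a step. Going by the values given here, no step between measured compounds that differ in one place is available, and the two measured compounds differ at more than one place from each other.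

The next compound, compound 3, `Nc1ccc2cccc(OCC3CCOC3)c2n1`, still unmeasured in this assay, differs from compound 1 in one place:
oxolan-3-yl in place of butyl on a saturated chain carbon bound to an oxygen on an aromatic ring
The change keeps the shared core of compound 1 and the aromatic amine on it, and only swaps the chain on the ether for a saturated ring bearing one oxygen. Among the compounds with values here, no measured step speaks to such a swap, so the expected effect in this assay is of modest size, in either direction or none beyond the scatter. The step from compound 1 to compound 3 is estimated at a 1.6-fold higher number from compound 1 to compound 3 (0.19 log units; within the scatter). Compound 3 is therefore expected to give roughly 900 nM, within 300 nM to 3000 nM.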

Compound 3, half-maximal inhibitory concentration: 115 nM
Compound 3: the middle estimate sits 7.8-fold (0.89 log units) above what was measured, outside the stated range (below it).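

In this assay, for the compounds shown here, the ether chain on the shared core is the first place where a change in one place can be read: oxolan-3-yl in place of butyl gives a 5.0-fold lower number from compound 1 to compound 3 (0.70 log units; beyond the scatter). This place therefore accepts a saturated ring, and the gain lies beyond the scatter, so the chain here is not limited to an open hydrocarbon such as the butyl of compound 1. The entering group differs from butyl in three counted ways, with one more heavy atom, one five-membered non-aromatic ring and 1 hydrogen-bond acceptor, and nothing measured in the series bears on which of these accounts for the step.

Ring and oxygen enter together in compound 3, so it remains open whether the all-carbon cyclopentyl would hold the gain or whether an open chain carrying an ether oxygen, such as methoxyethyl, would reach it without any ring. Going by these compounds, it is equally open how a ring nitrogen, as in pyrrolidinyl, or a larger ring such as oxanyl would read at this place on the core of compound 3.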